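Cyanosulfanyl in place of formyl on the shared core

A few compounds are considered here, and "the series" means these few. Any claim that something is new, unique, unknown or untested is made for them only; others in the source may bear on it.

Compound 2 `O=Cc1c(-c2cc3ccccc3oc2=O)nc2sc(Cc3ccc(Cl)cc3)nn12` is characterised in an ADME assay on CCRF-CEM cells (Homo sapiens) for cytotoxicity, with a stated time of 72 h (a higher number here means a weaker inhibitor, a lower number a stronger inhibitor), where compound 2 gives 750 nM. This is the lowest of the two numbers recorded; the nearest is compound 1 `O=c1oc2ccccc2cc1-c1nc2sc(Cc3ccc(Cl)cc3)nn2c1Br`, which in this assay gives 3700 nM. Among the compounds with values here, the single measured step, formyl in place of bromo on an aromatic carbon, produced a 4.9-fold lower number from compound 1 to compound 2 (0.69 log units; beyond the scatter), a modest shift. Compound 3 `N#CSc1c(-c2cc3ccccc3oc2=O)nc2sc(Cc3ccc(Cl)cc3)nn12` carries cyanosulfanyl in place of formyl on an aromatic carbon. Within the data shown here, no measured step involves a cyanosulfanyl group, so this change has no direct precedent; the only guide is that the one recorded substitution at this carbon moved the number modestly and beyond the scatter. A step of similar size cannot be ruled out in either direction, and none beyond the scatter is the most cautious reading. For compound 3 in this assay the estimate is 1500 nM, with a range from 400 nM to 6000 nM, which is expected to mean a step of a 2.0-fold higher number from compound 2 to compound 3 (0.30 log units; within the scatter).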

Compound 3, half-maximal inhibitory concentration: 1400 nM
Estimate against measurement, compound 3: 1.1-fold (0.03 log units) above; measured number inside the range.
By their numbers in this assay, from the lowest: compounds 2 and 3 (each within the scatter of the next); then compound 1.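

In this assay the change from formyl to cyanosulfanyl on this aromatic carbon amounts to a 1.9-fold higher number from compound 2 to compound 3 (0.27 log units; within the scatter) and so does not separate the two compounds, even though a double bond leaves and a triple bond enters. Bromo now stands apart from two different groups rather than one, with a 2.6-fold lower number from compound 1 to compound 3 (0.42 log units; beyond the scatter) alongside a 4.9-fold lower number from compound 1 to compound 2 (0.69 log units; beyond the scatter) as the earlier step. Nothing available explains why these groups read as they do.

On these data alone, whether an amine, a carboxylic acid or a longer chain on this carbon would read with formyl and cyanosulfanyl or with bromo remains open. So does how a plain hydrogen at this place would compare with all three.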